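Extending the long chain of compound 2

This account rests on a few compounds, and the source may have more. Where it says the series, first, only, none or still open, it means among the compounds named here.

Within the data shown here, only two compounds have numbers so far. In a functional assay on WM164 cells (Homo sapiens) for antiproliferative activity, read by sulforhodamine B assay, with a stated time of 48 h (a lower number here means a stronger inhibitor, a higher number a weaker inhibitor), compound 1 (`CCCCCCCCCCCCCCCCNC(=O)[C@@H]1CSC(c2ccc(OC)c(OC)c2)N1`) gives 500 nM and compound 2 (`CCCCCCCCCCCCCCNC(=O)[C@@H]1CSC(c2ccccc2)N1`) gives 600 nM so the pair lies within the usual scatter of repeated measurements and cannot be ranked. Among the measured compounds shown here, compound 2 therefore stands level with the only other number available.

The next compound is compound 3 (`CCCCCCCCCCCCCCCCNC(=O)[C@@H]1CSC(c2ccccc2)N1`). The change from compound 2 is ethyl in place of hydrogen on a saturated chain carbon, ten or more bonds along the chain from an amide-type nitrogen and it places ethyl in place of hydrogen on a saturated chain carbon, ten or more bonds along the chain from an amide-type nitrogen. The result is a longer chain with nothing else altered.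

For the measured compounds named here, no measured pair shows a change of this kind, so the data offer only weak guidance. The expectation in this assay is no step beyond the scatter, in either direction. The expected step of a 1.2-fold higher number from compound 2 to compound 3 (0.07 log units; within the scatter) is small and stays within that scatter. For compound 3 the estimated value is 700 nM with an expected range from 350 nM to 1500 nM.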

Compound 3, half-maximal inhibitory concentration: 700 nM
Compound 3: the middle estimate sits on the measured number at the digits printed; the range from low to high includes it.
By their numbers in this assay, from the lowest: compounds 1, 2 and 3 (each within the scatter of the next).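

In this assay, ethyl in place of hydrogen on a saturated chain carbon, ten or more bonds along the chain from an amide-type nitrogen, gives a 1.2-fold higher number from compound 2 to compound 3 (0.07 log units; within the scatter). This lengthening of the chain therefore cannot be told apart from repeat-measurement noise, so the assay shows no sensitivity to this particular change at this chain length. Among these compounds, compound 3 also provides the first pair that differs only in the aromatic group: phenyl in place of 3,4-dimethoxyphenyl on a saturated ring carbon gives a 1.4-fold higher number from compound 1 to compound 3 (0.15 log units; within the scatter), so these two groups cannot be ranked here, and no separate measurement is available to explain either result.

The compounds shown leave open what a much shorter chain, or a chain ending in an amine or a carboxylic acid, would do to the number in this assay. They also leave open whether a different group on the phenyl ring, such as chloro or hydroxyl, would produce a step beyond the scatter.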